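Ethylsulfanyl for Bromo on the Cyanophenyl Ring

A few compounds are considered here, and "the series" means these few. Any claim that something is new, unique, unknown or untested is made for them only; others in the source may bear on it.

Measured compounds in a functional assay on CHO cells for inhibition of metabotropic glutamate receptor 5 (Rattus norvegicus), read by FLIPR and calcium flux; on this read-out lower numbers stand for stronger inhibition and higher numbers for weaker inhibition:
compound 1 `Cc1ccc2ccc(-c3cc(F)cc(C#N)c3)cc2n1` gives 0.8 nM;
compound 2 `COc1cc(C#N)cc(-c2ccc3ccc(C)nc3c2)c1` gives 2.4 nM;
compound 3 `Cc1ccc2ccc(-c3cc(Br)cc(C#N)c3)cc2n1` gives 13 nM.

Compound 3 stands highest of the three: its number lies a 5.4-fold higher number from compound 2 to compound 3 (0.73 log units; beyond the scatter) and a 16-fold higher number from compound 1 to compound 3 (1.21 log units; beyond the scatter). Compound 4 `CCSc1cc(C#N)cc(-c2ccc3ccc(C)nc3c2)c1` differs from compound 3 by one change: ethylsulfanyl in place of bromo on an aromatic carbon. For the measured compounds named here, two measured steps bear on this position. Going by the values given here, replacing the halogen with methoxy gave a 3.0-fold higher number from compound 1 to compound 2 (0.48 log units; beyond the scatter), while going from methoxy to bromo gave a 5.4-fold higher number from compound 2 to compound 3 (0.73 log units; beyond the scatter); both show that a heteroatom-linked group is tolerated better than bromo here, though no sulfur group has yet been tested. A step downward from compound 3 to compound 4 is therefore expected, estimated as a 2.6-fold lower number from compound 3 to compound 4 (0.41 log units; beyond the scatter). For compound 4 in this assay the estimate is 5 nM, with a range from 1.5 nM to 20 nM.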

Compound 4, half-maximal inhibitory concentration: 72 nM
Estimate against measurement, compound 4: 14-fold (1.16 log units) below; the measured number lies above the stated range.
By their numbers in this assay, from the lowest: compound 1; then compound 2; then compound 3; then compound 4.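

In this assay ethylsulfanyl is the least tolerated of the four groups at this position, with a 5.5-fold higher number from compound 3 to compound 4 (0.74 log units; beyond the scatter), a 30-fold higher number from compound 2 to compound 4 (1.48 log units; beyond the scatter) and a 90-fold higher number from compound 1 to compound 4 (1.95 log units; beyond the scatter). A heteroatom link therefore does not by itself secure a better result than bromo: methoxy does, while ethylsulfanyl goes against it. No measurement offered here explains the loss. The compounds shown leave open whether the sulfur or the ethyl chain carries the loss; methylsulfanyl and ethoxy are the groups that would separate the two.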